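Swapping the Basic Ring on the Chain

The source may hold more compounds than are shown below. What is called first, only, known or untested is meant among the compounds shown, and "the series" means these compounds.

Three compounds share one core and differ only in the amine carried on the chain that leaves an oxygen on an aromatic ring. In an assay on isolated protein for inhibition of advanced glycosylation end product-specific receptor (Homo sapiens), read by FRET, with stated times of 30 min and 1 h, tested at 4 uM (on this read-out higher numbers stand for more inhibition at the one concentration tested (going by the name of the read-out) and lower numbers for less inhibition), compound 1 `CC(C)N1CCC(COc2ccc(-c3nc4ccc(Oc5ccc(Cl)cc5)cc4o3)cc2)CC1` gives 26.2%. Compound 2 `Clc1ccc(Oc2ccc3nc(-c4ccc(OCCCN5CCCC5)cc4)oc3c2)cc1` is reported in this assay as "not active" (no number reported), with no number attached. Compound 3 `CC(C)(C)C1CCN(CCCOc2ccc(-c3nc4ccc(Oc5ccc(Cl)cc5)cc4o3)cc2)CC1` gives 16.6% in this assay. Going by the values given here, compound 3 thus holds the lower of the two numbers recorded, yet the one single-change step available, a number 9.6 percentage points lower from compound 1 to compound 3 (within the scatter), lies within the scatter, so compound 1 and compound 3 cannot be told apart on this read-out.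

Compound 4 `CN1CCN(CCCOc2ccc(-c3nc4ccc(Oc5ccc(Cl)cc5)cc4o3)cc2)CC1` follows from compound 3 by 4-methylpiperazin-1-yl in place of 4-(tert-butyl)piperidin-1-yl on a saturated chain carbon, three bonds along the chain from an oxygen on an aromatic ring. Among the compounds with values here, no measured step covers this exact exchange. The step that bears on it, a number 9.6 percentage points lower from compound 1 to compound 3 (within the scatter), replaced one amine with another and stayed within the scatter; compound 2, which carries yet another amine on the same chain, returned no number at all. The amine has so far shifted the read-out little, so no movement beyond the scatter is expected for compound 4 in this assay. Compound 4 is therefore estimated at 13%, within a range of 0% to 30%. The expected step is a number 3.6 percentage points lower from compound 3 to compound 4 (within the scatter).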

Compound 4, a percentage reported as inhibition, at one concentration (the size of the read-out at that concentration, not a potency): 24.3%
Estimate against measurement, compound 4: 11.3 percentage points below; measured number inside the range.
By their numbers in this assay, from the lowest: compounds 3, 4 and 1 (each within the scatter of the next).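

In this assay, placing 4-methylpiperazin-1-yl in place of 4-(tert-butyl)piperidin-1-yl at this place on the chain gives a number 7.7 percentage points higher from compound 3 to compound 4 (within the scatter) and so adds a second ring nitrogen and removes the tert-butyl group without any change that can be told apart on this read-out. The other new comparison, a number 1.9 percentage points lower from compound 1 to compound 4 (within the scatter) for 2-(4-methylpiperazin-1-yl)ethyl in place of 1-isopropylpiperidin-4-yl, also stays within the scatter, so the three compounds with numbers, each carrying a different amine, cannot be separated, while compound 2 still stands apart only as an entry without a number. No evidence is available to explain why these different amines read alike.

As far as these compounds go, whether a morpholine or an open-chain amine such as dimethylamine at the end of the chain would move the read-out beyond the scatter remains open, as does the outcome of a carboxylic acid in place of the amine. The compounds shown also leave open whether a longer chain between the oxygen and the amine would matter.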